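The source may hold more compounds than are shown below. What is called first, only, known or untested is meant among the compounds shown, and "the series" means these compounds.

Measured compounds:
compound 1 `Cc1cccc(C(=O)NN(C(=O)c2ccccc2Cl)C(C)(C)C)c1C` gives 20 nM in an assay on cells for agonist activity at ecdysone receptor (Bombyx mori), read by a luciferase reporter, with a stated time of 24 h; a lower number here means that less compound is needed, a higher number that more compound is needed for the effect
compound 2 `Cc1ccc(C)c(C(=O)NN(C(=O)c2ccccc2Cl)C(C)(C)C)c1` gives 1620 nM in this assay

Within the data shown here, compound 2 stands at the higher of the two numbers, and the only measured step, an 81-fold higher number from compound 1 to compound 2 (1.91 log units; beyond the scatter), separates it from compound 1 by a wide margin. Compound 3 `Cc1ccc(C(=O)NN(C(=O)c2ccccc2Cl)C(C)(C)C)cc1C` differs from compound 2 in one place: 3,4-dimethylphenyl in place of 2,5-dimethylphenyl on a carbonyl carbon. Among the measured compounds shown here, the one measured step bears on this change only indirectly: it shows that moving the methyl groups around the ring can shift the number a great deal, but it does not tell in which direction a 3,4-dimethylphenyl will move it. On these data alone, the largest swing in the set therefore sets the scale of what may happen, while the direction remains open. Compound 3 is expected to fall between the two measured numbers, nearer to compound 1 than compound 2 is, with an estimated 150 nM in this assay and a range from 20 nM to 1500 nM; this would mean an estimated step of an 11-fold lower number from compound 2 to compound 3 (1.03 log units; beyond the scatter).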

Compound 3, half-maximal effective concentration: 87.1 nM
Compound 3: the middle estimate sits 1.7-fold (0.24 log units) above what was measured, within the range that was stated.
By their numbers in this assay, from the lowest: compound 1; then compound 3; then compound 2.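

In this assay the change to 3,4-dimethylphenyl on a carbonyl carbon gives a 19-fold lower number from compound 2 to compound 3 (1.27 log units; beyond the scatter) and so shows a second large shift at this position, among groups with the same atoms joined differently. Set against 2,3-dimethylphenyl, the same group gives a 4.4-fold higher number from compound 1 to compound 3 (0.64 log units; beyond the scatter) as a modest step, so two of the three arrangements of the methyl groups lie much closer to each other than either does to 2,5-dimethylphenyl. No evidence at hand explains why these arrangements of the two methyl groups differ.

Still open, on these data alone, is how a phenyl carrying one methyl group, or carrying methoxy or ethyl groups in place of the methyl groups, would stand in this order. As far as these compounds go, the rest of the core is the same in all three compounds, so it also remains open whether the order would hold with another group there.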